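Adding a Hydroxymethyl to the Fluorophenyl of Compound 2

A few compounds are considered here, and "the series" means these few. Any claim that something is new, unique, unknown or untested is made for them only; others in the source may bear on it.

Measured so far:
Compound 1, `COc1ccc(-c2cc(Cl)cc(Cl)c2/C=C/[C@@H]2C[C@@H](O)CC(=O)O2)cc1`: 470 nM
Compound 2, `Cc1cc(C)c(/C=C/[C@@H]2C[C@@H](O)CC(=O)O2)c(-c2ccc(F)cc2)c1`: 13 nM

Both were tested in an assay for inhibition of 3-hydroxy-3-methylglutaryl-coenzyme A reductase (Rattus norvegicus); on this read-out higher numbers stand for weaker inhibition and lower numbers for stronger inhibition. Compound 2 stands lowest of the two numbers, and compound 1 gives a much higher number, a gap beyond the usual scatter. Compound 3, `Cc1cc(C)c(/C=C/[C@@H]2C[C@@H](O)CC(=O)O2)c(-c2ccc(F)c(CO)c2)c1`, is not yet measured. It differs from compound 2 in one place: hydroxymethyl in place of hydrogen on an aromatic carbon. Cut one bond further out, the same difference reads 4-fluorophenyl to 4-fluoro-3-(hydroxymethyl)phenyl. Within the data shown here, no measured pair shows this change, so its size cannot be read from the data. The expected step is a 1.9-fold higher number from compound 2 to compound 3 (0.28 log units; within the scatter), a modest weakening that may still fall within the scatter. Compound 3 is estimated at 25 nM, within a range of 8 nM to 80 nM.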

Compound 3, half-maximal inhibitory concentration: 49 nM
The estimate for compound 3 lay 2.0-fold (0.29 log units) below the measured number; measured number inside the range.
By their numbers in this assay, from the lowest: compound 2; then compound 3; then compound 1.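

In this assay, among these compounds, the change gives a 3.8-fold higher number from compound 2 to compound 3 (0.58 log units; beyond the scatter) and this is the first measured step at this position, so the aromatic carbon ortho to the fluoro group is not indifferent to what it carries. Hydroxymethyl there weakens inhibition without abolishing it, since compound 3 still reads 49 nM on this read-out. Nothing available explains the size of this step. Still open, from the compounds shown here alone, is whether the hydroxyl or the added carbon accounts for the step. A methyl group, an amine or a carboxylic acid on the same carbon could help separate these possibilities.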